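The source may hold more compounds than are shown below. What is called first, only, known or untested is meant among the compounds shown, and "the series" means these compounds.

Measured compounds and values in an ADME assay on MDBK cells (Bos taurus) for cytotoxicity, read by MTT assay, with a stated time of 96 h; a higher number here means that more compound is tolerated, a lower number that less compound is tolerated:
compound 1, `C/C(=N\NC(N)=S)c1ccc2[nH]c(-c3ccc(C(F)(F)F)cc3)nc2c1`, gives 5000 nM.
compound 2, `COc1ccc(-c2nc3cc(/C(C)=N/NC(N)=S)ccc3[nH]2)cc1`, gives 13000 nM.
compound 3, `C/C(=N\NC(N)=O)c1ccc2c(c1)nc(-c1ccc(C(F)(F)F)cc1)n2C1CCCCC1`, is reported only as a limit of this assay, > 100000 nM.

Compound 1 and compound 2 share their core and differ in one place: methoxy in place of trifluoromethyl on an aromatic carbon. In this assay that change made a 2.6-fold higher number from compound 1 to compound 2 (0.41 log units; beyond the scatter), so the methoxy compound is tolerated at a higher concentration.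

Compound 4, `COc1ccc(-c2nc3cc(/C(C)=N/NC(N)=O)ccc3n2C2CCCCC2)cc1`, has not yet been measured. It differs from compound 3 by methoxy in place of trifluoromethyl on an aromatic carbon. Against the pair of compound 1 and compound 2, the change is of the same kind rather than the same: here the same difference, cut one bond further out, reads 4-(trifluoromethyl)phenyl to 4-methoxyphenyl. The cores of compound 3 and compound 1 differ in more than one place, and that difference is not broken down here.

For the expectation, compound 3 already sits at the limit of > 100000 nM in this assay, at which 1 of the 3 values shown sits, and the measured change of this kind raised the number in the direction of more tolerance. Compound 4 is therefore expected to be reported as a limit again, or at most to stand somewhat above compound 3; the estimated step is a step that the limit leaves unreadable from compound 3 to compound 4. Compound 4 is estimated at 160000 nM in this assay, with a range from 70000 nM to 400000 nM.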

Compound 4, half-maximal cytotoxic concentration: 54000 nM
Compound 4: middle estimate off by 3.0-fold (0.47 log units), on the high side; measured number below the stated range.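

In this assay, methoxy in place of trifluoromethyl on the core of compound 3 gave an at least 1.8-fold lower number from compound 3 to compound 4 (0.26 log units; that floor lies within the scatter), which runs opposite in direction to the step on the core of compound 1, so in this series the change does not carry from one core to the other as a fixed step: the same change on two cores in this assay, a 2.6-fold higher number (0.41 log units; beyond the scatter) from compound 1 to compound 2 and an at least 1.8-fold lower number (0.26 log units; that floor lies within the scatter) from compound 3 to compound 4, at least 4.8-fold (0.68 log units) apart, beyond the scatter of two such steps

Compound 3 is reported only as a limit, > 100000 nM.

The new step is therefore a floor with its full size unread, and two pairs whose cores differ in more than one place do not show which core difference goes with the change of direction, or whether the split would hold on any further core.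

Still open, as far as these compounds go, is how each core difference reads alone, which would need a pair of compounds differing in that one place, with trifluoromethyl and methoxy compared on each side. Also open, from the compounds shown here alone, is whether the split is particular to these two groups, since a nitrile, an amine or a carboxylic acid in the same place, para to a large group, could show whether other replacements for trifluoromethyl also read differently on the two cores in this assay.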